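The source may hold more compounds than are shown below. What is called first, only, known or untested is meant among the compounds shown, and "the series" means these compounds.

Compound 1 `O=C(CCc1cccc2c1B(O)OC2)Nc1ccccc1` is the reference of this series. In a functional assay on HCT-116 cells (Homo sapiens) for antiproliferative activity, read by MTT assay, with a stated time of 72 h (a higher number here means a weaker inhibitor, a lower number a stronger inhibitor), compound 1 gives 350 nM, the lowest of the two numbers recorded. Compound 2 `O=C(CCc1cccc2c1B(O)OC2)Nc1ccc(Br)cc1` gives 46000 nM in this assay, and the step of a 130-fold higher number from compound 1 to compound 2 (2.12 log units; beyond the scatter) is large. Compound 3 `CCOC(=O)c1ccc(NC(=O)CCc2cccc3c2B(O)OC3)cc1` returns only a limit of the assay, > 100000 nM, in this assay. The step of an at least 280-fold higher number from compound 1 to compound 3 (2.45 log units; beyond the scatter) is therefore also large, and the limit of > 100000 nM in this assay, at which 1 of the 3 values shown sits, marks the ceiling reached.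

Compound 4 `O=C(CCc1cccc2c1B(O)OC2)Nc1cccc(-c2ccc(Cl)cc2)c1` differs from compound 1 by 4-chlorophenyl in place of hydrogen on an aromatic carbon. Both measured substitutions on the same ring of compound 1 weakened inhibition heavily, so a large upward step is expected here as well, a 29-fold higher number from compound 1 to compound 4 (1.46 log units; beyond the scatter), and compound 4 is estimated at 10000 nM in this assay, within 1000 nM to 100000 nM.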

Compound 4, half-maximal inhibitory concentration: 380 nM
Compound 4: middle estimate off by 26-fold (1.42 log units), on the high side, and the stated range ends above it.
By their numbers in this assay, from the lowest: compounds 1 and 4 (each within the scatter of the next); then compound 2. At a limit, above all of these: compound 3.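

In this assay, a 1.1-fold higher number from compound 1 to compound 4 (0.04 log units; within the scatter), so 4-chlorophenyl, meta to a large group, is tolerated on this ring. Substitution on this ring therefore need not carry the large cost seen in compounds 2 and 3, even with 7 heavy atoms entering. No measured property available here bears on this result.

Open, on these data alone, is whether the large steps of compounds 2 and 3 belong to the groups or to their place on the ring. Also open, as far as these compounds go, is whether an amine or a carboxylic acid at the position of the 4-chlorophenyl would stay within the scatter of compound 1.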